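The source may hold more compounds than are shown below. What is called first, only, known or untested is meant among the compounds shown, and "the series" means these compounds.

Measured in a functional assay on SW-620 cells (Homo sapiens) for cytotoxicity, read by sulforhodamine B assay, with a stated time of 48 h; on this read-out lower numbers stand for stronger inhibition and higher numbers for weaker inhibition:
- compound 1 `C[C@H]1CC[C@@H]2[C@@H](OC(=O)[C@]23CC(c2ccc(Cl)cc2)=NO3)[C@]2(C)C(=O)C=C[C@@]12O`: 51000 nM
- compound 2 `C[C@H]1CC[C@@H]2[C@@H](OC(=O)[C@]23CC(c2ccc(N(C)C)cc2)=NO3)[C@]2(C)C(=O)C=C[C@@]12O`: 5100 nM
- compound 3 `COc1cc(C2=NO[C@]3(C2)C(=O)O[C@@H]2[C@H]3CC[C@H](C)[C@]3(O)C=CC(=O)[C@@]23C)ccc1O`: 88000 nM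

Compound 3 stands at 88000 nM. The comparison with the 4-chlorophenyl analogue gives a 1.7-fold higher number from compound 1 to compound 3 (0.24 log units; within the scatter). The comparison with the 4-(dimethylamino)phenyl analogue gives a 17-fold higher number from compound 2 to compound 3 (1.24 log units; beyond the scatter). So only the dimethylamino compound stands apart from the other two.

Next is compound 4 `C[C@H]1CC[C@@H]2[C@@H](OC(=O)[C@]23CC(c2ccc(F)cc2)=NO3)[C@]2(C)C(=O)C=C[C@@]12O`, which has 4-fluorophenyl in place of 4-hydroxy-3-methoxyphenyl on a carbon with a double bond to nitrogen.

Going by the values given here, no fluoro compound has been measured, so the closest guide is compound 1, which also carries a single halogen on the phenyl group. Exchanging that 4-chlorophenyl for 4-hydroxy-3-methoxyphenyl gave a 1.7-fold higher number from compound 1 to compound 3 (0.24 log units; within the scatter), so this exchange of groups did not move the number beyond the scatter. The two larger steps, a 10-fold lower number from compound 1 to compound 2 (1.00 log units; beyond the scatter) and a 17-fold higher number from compound 2 to compound 3 (1.24 log units; beyond the scatter), both involve the dimethylamino group, which plays no part in the present change. They are therefore given little weight here.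

The expected change is a 1.8-fold lower number from compound 3 to compound 4 (0.25 log units; within the scatter), which would be no step beyond the scatter. Compound 4 is estimated at 50000 nM, with an expected range of 20000 nM to 100000 nM.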

Compound 4, half-maximal inhibitory concentration: 3600 nM
Compound 4: middle estimate off by 14-fold (1.14 log units), on the high side; the whole stated range lies above it.
By their numbers in this assay, from the lowest: compounds 4 and 2 (each within the scatter of the next); then compounds 1 and 3 (each within the scatter of the next).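

In this assay the group on the carbon with a double bond to nitrogen proves able to move the number without any dimethylamino group: 4-fluorophenyl in place of 4-hydroxy-3-methoxyphenyl gives a 24-fold lower number from compound 3 to compound 4 (1.39 log units; beyond the scatter) and fluoro in place of chloro on the aromatic carbon gives a 14-fold lower number from compound 1 to compound 4 (1.15 log units; beyond the scatter) as a large step between two halogens. Fluoro in place of dimethylamino gives a 1.4-fold lower number from compound 2 to compound 4 (0.15 log units; within the scatter) so a low number in this series does not depend on the dimethylamino group, and the earlier split of compound 2 against the other two now reads as compound 2 and compound 4 against compound 1 and compound 3. No measurement on these compounds is available to account for the separation of the fluoro and chloro compounds.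

Open, going by these compounds, is whether plain phenyl, or a lone hydroxy or lone methoxy group on the phenyl ring, would fall with compound 2 and compound 4 or with compound 1 and compound 3. Also open, on these data alone, is where a bromo, nitrile or carboxylic acid group on that aromatic carbon would stand.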